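A few compounds are considered here, and "the series" means these few. Any claim that something is new, unique, unknown or untested is made for them only; others in the source may bear on it.

Compound 1, `CCc1nc(-c2ccc(Cl)cc2Cl)c(CC)nc1NC(C1CC1)C1CC1`, was assayed in an in vitro ADME assay on microsomes (Homo sapiens) for metabolic stability (a lower number here means that the compound disappears faster, a higher number that the compound lasts longer), and gave a half-life of 0.183 h. Two further compounds share its core but carry pentan-3-yl on the ring nitrogen: compound 2, `CCc1nc(-c2ccc(OC)nc2OC)c(CC)nc1NC(CC)CC`, which in this assay gives 0.15 h, and compound 3, `CCc1nc(-c2ccc(OC(C)C)cc2OC)c(CC)nc1NC(CC)CC`, which in this assay gives 0.183 h. The three half-lives fall within the usual scatter of one another, so compound 1 cannot be set apart from either of them on these numbers.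

Compound 4, `CCc1nc(-c2ccc(Cl)cc2Cl)c(CC)nc1NC(CC)CC`, has not yet been measured. It differs from compound 1 by pentan-3-yl in place of dicyclopropylmethyl on a nitrogen on an aromatic ring. The change brings the amine of compound 4 into line with the amine already present in compounds 2 and 3, while the aryl group of compound 1 is retained. No difference beyond the scatter is expected in this assay for this step, since compound 2 at 0.15 h and compound 3 at 0.183 h sit close to compound 1. The half-life of compound 4 is therefore estimated at 0.16 h, with a range from 0.09 h to 0.3 h, the expected step being a 1.1-fold lower number from compound 1 to compound 4 (0.06 log units; within the scatter).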

Compound 4, half-life: 0.283 h
The estimate for compound 4 lay 1.8-fold (0.25 log units) below the measured number; the measured number falls inside the stated range.
By their numbers in this assay, from the lowest: compounds 2, 1, 3 and 4 (each within the scatter of the next).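

In this assay, among these compounds, the pair gives the first direct reading at this nitrogen: with the rest of the molecule unchanged, pentan-3-yl in place of dicyclopropylmethyl gives a 1.5-fold higher number from compound 1 to compound 4 (0.19 log units; within the scatter). With the aryl group of compound 1 in place, opening the substituent from one carrying two three-membered rings to one with no ring therefore leaves the half-life within the scatter, so these numbers do not separate the two groups. Nothing available explains how the two groups compare.

From the compounds shown here alone, whether the same exchange would read alike with the aryl groups of compound 2 and compound 3 stays open. Also open, going by these compounds, is how a different kind of group on this nitrogen, such as a cyclopentyl ring or a chain carrying an ether oxygen, would compare with these two.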